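Trimming a Sulfonamide Arm on a Calcium-Flux Antagonist

The source may report more compounds than this note shows. Statements on the series, on what has been measured and on what is new or still open speak of the compounds shown alone.

Of the compounds shown here, three sharing one core have been tested in a functional assay on U-937 cells (Homo sapiens) for antagonist activity, read by calcium flux; on this read-out lower numbers stand for stronger inhibition and higher numbers for weaker inhibition. Compound 1 `COc1ccc(CCCCCCCCOc2ccc(C[S+]([O-])c3cccc(NS(=O)(=O)c4ccccc4)c3)nc2/C=C/C(=O)O)cc1` gives 150 nM in this assay, the lowest of the three numbers and so the strongest inhibition seen here. Compound 3 `COc1ccc(CCCCCCCCOc2ccc(COc3cccc(C(=O)O)c3)[n+]([O-])c2/C=C/C(=O)O)cc1` gives 890 nM, a gap to compound 1 that lies beyond the usual scatter. Compound 2 `COc1ccc(CCCCCCOc2ccc(CC(O)c3cccc(C(=O)O)c3)nc2/C=C/C(=O)O)cc1` gives 4000 nM, the weakest of the three, again well beyond the scatter from compound 1. All three differ from one another in several places at once, so none of these gaps can be pinned to a single change.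

Compound 4 `COc1ccc(CCCCCCCCOc2ccc(C[S+]([O-])c3cccc(N(C)C)c3)nc2/C=C/C(=O)O)cc1` has not yet been measured. It differs from compound 1 in one place: dimethylamino in place of (phenylsulfonyl)amino on an aromatic carbon. A sizeable group carrying a hydrogen-bond donor and a second aromatic ring is swapped for a small group with no ring and no donor. Nothing in the measured set isolates this kind of change, so the expectation rests on the size of what is removed. A step toward weaker inhibition, beyond the scatter, is expected from compound 1 to compound 4 in this assay, a 5.3-fold higher number from compound 1 to compound 4 (0.73 log units; beyond the scatter). Compound 4 is therefore expected to give about 800 nM, within a range from 200 nM to 3000 nM.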

Compound 4, half-maximal inhibitory concentration: 820 nM
For compound 4 the middle estimate is 1.0-fold (0.01 log units) below the measured one; measured number inside the range.
By their numbers in this assay, from the lowest: compound 1; then compounds 4 and 3 (each within the scatter of the next); then compound 2.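

Going by these compounds alone, the swap at this aromatic carbon is the first change in the set that can be read on its own: compound 1 and compound 4 differ nowhere else. In this assay, replacing (phenylsulfonyl)amino with dimethylamino brings a 5.5-fold higher number from compound 1 to compound 4 (0.74 log units; beyond the scatter) and thus weaker inhibition, which shows that the group at this position matters to the read-out, yet compound 4 still gives a measurable inhibitory value of 820 nM without the second aromatic ring. No measurement at hand explains why the inhibition weakens.

This single step removes several things together: the aromatic ring, the sulfonyl group and the hydrogen-bond donor all leave at once, so the compounds shown cannot say which of them accounts for the difference. A methylsulfonylamino group would keep the sulfonyl link and the amide-type hydrogen while dropping the ring, and an unsubstituted amino group or an acetylamino group at the same carbon would help separate these parts, as would any of these swaps made on the other side chains of the shared core.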